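The source may report more compounds than this note shows. Statements on the series, on what has been measured and on what is new or still open speak of the compounds shown alone.

Measured compounds:
compound 1, `COc1cccc(OC)c1OCCNCCOc1ccccc1OCc1ccccc1Cl`: 5400 nM
compound 2, `COc1cccc(OC)c1OCCNCCOc1ccccc1OCc1ccc(Cl)cc1`: 2400 nM

Both were tested in a functional assay on PC-3 cells (Homo sapiens) for cytotoxicity, read by sulforhodamine B assay; a higher number here means a weaker inhibitor of growth, a lower number a stronger inhibitor of growth. Going by the values given here, compound 2 holds the lowest of the two numbers, and the only measured step, a 2.3-fold lower number from compound 1 to compound 2 (0.35 log units; beyond the scatter), moves the chloro group within the ring rather than replacing it. Compound 3, `COc1cccc(OC)c1OCCNCCOc1ccccc1OCc1cccc([N+](=O)[O-])c1`, differs from compound 2 as follows: 3-nitrophenyl in place of 4-chlorophenyl on a saturated chain carbon bound to an oxygen on an aromatic ring. Among the compounds with values here, no measured pair shows a chlorine exchanged for a nitro group, so the measured step does not bear directly on this change; it only shows that a modest shift in this part of the molecule gave a modest movement in the numbers. A step of similar or smaller size is therefore expected here, with no clear direction, so the estimated step is a 1.3-fold higher number from compound 2 to compound 3 (0.10 log units; within the scatter). Compound 3 is estimated at 3000 nM, within a range from 1200 nM to 8000 nM.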

Compound 3, concentration for 50% growth inhibition: 13200 nM
Beside the measured number, compound 3's estimate is 4.4-fold (0.64 log units) below it; measured number outside the range, above it.
By their numbers in this assay, from the lowest: compound 2; then compound 1; then compound 3.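

The new number shows that this part of the molecule can move growth inhibition further than the chlorine shift alone suggested: replacing 4-chlorophenyl with 3-nitrophenyl gives a 5.5-fold higher number from compound 2 to compound 3 (0.74 log units; beyond the scatter), a larger step than the one between the two chlorinated compounds. The 3-nitrophenyl compound also falls behind the weaker of those two, with a 2.4-fold higher number from compound 1 to compound 3 (0.39 log units; beyond the scatter), so both chlorophenyl compounds give lower numbers than compound 3. Nothing measured here explains this rise.

This change alters both the substituent and its place on the ring, so the compounds shown cannot separate those two effects; a 3-chlorophenyl or 4-nitrophenyl compound would help to do so. On these data alone, it also remains open how an amine or a carboxylic acid on this ring would affect the number.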